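The compounds below may be only part of what the source reports. "The series", "measured", "known", "first", "only" and "open" are said of these compounds alone.

Compound 1 `C[C@H](C(=O)Nc1cc(C2CC2)[nH]n1)c1ccc(N2CCCC2)cc1`: 220 nM
Compound 2 `CC(C(=O)Nc1cc(C2CC2)[nH]n1)c1ccc(N2CCCC2)cc1`: 370 nM

Among the compounds with values here, in a functional assay on A2780 cells (Homo sapiens) for inhibition (a lower number here means a stronger inhibitor, a higher number a weaker inhibitor), compound 2 stands level with compound 1, the only other measured member of the series: the gap is a 1.7-fold higher number from compound 1 to compound 2 (0.23 log units; within the scatter). Compound 3 `CC(C(=O)Nc1cc(C2CC2)[nH]n1)c1ccc(-n2cnnc2O)cc1` keeps the core of compound 2 and changes one group: a group of 6 heavy atoms (2 carbon, 3 nitrogen, 1 oxygen; one five-membered aromatic ring with 3 hetero atoms) in place of a group of 5 heavy atoms (4 carbon, 1 nitrogen; one five-membered non-aromatic ring with 1 hetero atom), on an aromatic carbon. Pyrrolidin-1-yl leaves an aromatic carbon of a six-membered aromatic ring of carbon only, para to a large group, and a five-membered aromatic ring with 3 hetero atoms enters there.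

Within the data shown here, the one measured step goes with the fact that one of compounds 1 and 2 is drawn with a defined configuration and the other without, at the place where they differ, and it does not touch this position. Among the measured compounds shown here, no measured step therefore shows what a replacement at this position does. For the measured compounds named here, the only anchor is compound 2 at 370 nM, so the expectation is loose: a move to a higher number in this assay, beyond the scatter, with a wide range. The expected step is a 3.2-fold higher number from compound 2 to compound 3 (0.51 log units; beyond the scatter). For compound 3 the estimated value is 1200 nM, with an expected range of 300 nM to 5000 nM.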

Compound 3, half-maximal inhibitory concentration: 8390 nM
Beside the measured number, compound 3's estimate is 7.0-fold (0.84 log units) below it, outside the stated range (above it).
By their numbers in this assay, from the lowest: compounds 1 and 2 (each within the scatter of the next); then compound 3.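

In this assay, the position on an aromatic carbon of a six-membered aromatic ring of carbon only, para to a large group, does not tolerate every replacement: exchanging pyrrolidin-1-yl for the five-membered aromatic ring with 3 hetero atoms gives a 23-fold higher number from compound 2 to compound 3 (1.36 log units; beyond the scatter). Within the data shown here, this is the first measured step at this position, since the only earlier one, a 1.7-fold higher number from compound 1 to compound 2 (0.23 log units; within the scatter), concerns the drawn configuration and leaves this group unchanged. The change replaces a non-aromatic ring with 0 hydrogen-bond donors and 1 hydrogen-bond acceptor by an aromatic ring with 1 hydrogen-bond donor and 4 hydrogen-bond acceptors, neither with a net charge, but nothing measured here accounts for the loss.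

A single replacement cannot separate the contributions of the ring type, the added oxygen and the donor and acceptor counts to this step. As far as these compounds go, it also remains open where groups such as morpholin-4-yl, dimethylamino or a carboxylic acid would fall at this position, and whether any replacement can match the number of compound 2 at 370 nM.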